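The source may hold more compounds than are shown below. What is called first, only, known or untested is meant among the compounds shown, and "the series" means these compounds.

Working notes on the series. In an assay for inhibition of gamma-butyrobetaine dioxygenase (Homo sapiens), read by HPLC, with stated times of 15 min and 30 min (a lower number here means a stronger inhibitor, a higher number a weaker inhibitor), compound 1 `CC[N+](C)(C)NCCC(=O)[O-]` gives 140000 nM. Compound 2 `CC(C)[N+](C)(C)NCCC(=O)[O-]` is reported only as a limit of this assay, > 1000000 nM, as noted in the limit of > 1000000 nM in this assay, at which 1 of the 3 values shown sits. The change from compound 1 to compound 2 is methyl in place of hydrogen on a saturated chain carbon bound to an amine nitrogen and a saturated chain carbon and gives an at least 7.1-fold higher number from compound 1 to compound 2 (0.85 log units; beyond the scatter). Compound 3 `CN(CCC(=O)[O-])[N+](C)(C)C` gives 90 nM in this assay, the lowest number among the measured compounds; the difference between the cores of compound 1 and compound 3 is not broken down here. Compound 4 `CC[N+](C)(C)N(C)CCC(=O)[O-]` is not yet measured; it differs from compound 3 by methyl in place of hydrogen on a saturated chain carbon bound to an amine nitrogen, the same kind of change as from compound 1 to compound 2, although there the carbon was bound to an amine nitrogen and a saturated chain carbon, whereas here it is bound to an amine nitrogen only. Resting on the loss seen from compound 1 to compound 2, a weakening is expected, estimated as a 20-fold higher number from compound 3 to compound 4 (1.30 log units; beyond the scatter). Compound 4 is therefore estimated at 1800 nM, expected between 300 nM and 15000 nM.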

Compound 4, half-maximal inhibitory concentration: 7200 nM
Beside the measured number, compound 4's estimate is 4.0-fold (0.60 log units) below it, within the range that was stated.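

In this assay, on these data alone, the change raises the number on both cores, so its direction carries over within these two pairs: the same change on two cores in this assay, an at least 7.1-fold higher number (0.85 log units; beyond the scatter) from compound 1 to compound 2 and an 80-fold higher number (1.90 log units; beyond the scatter) from compound 3 to compound 4; the limit leaves it open whether they differ Compound 2 is reported only as a limit, > 1000000 nM, so the size of the change on the core of compound 1 remains unknown and no equal or unequal size can be claimed. The exact size, an 80-fold higher number from compound 3 to compound 4 (1.90 log units; beyond the scatter), therefore applies only to the core of compound 3, while methyl in place of hydrogen on an amine nitrogen is a separate change, a 19-fold lower number from compound 1 to compound 4 (1.29 log units; beyond the scatter).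

The compounds shown leave open how a propyl chain in place of ethyl would read on the core of compound 3. They also leave open whether the same change holds with an ester in place of the carboxylate.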